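The source may report more compounds than this note shows. Statements on the series, on what has been measured and on what is new or still open speak of the compounds shown alone.

Measured in a functional assay on DU-145 cells (Homo sapiens) for inhibition, read by trypan blue exclusion, with a stated time of 72 h; a higher number here means a weaker inhibitor, a lower number a stronger inhibitor:
compound 1 `Cn1c(=O)c(C(=O)Nc2ccc(F)cc2)cc2cnc(Nc3ccc4[nH]ccc4c3)nc21`: 5000 nM
compound 2 `Cn1c(=O)c(S(=O)(=O)c2ccc(F)cc2)cc2cnc(Nc3ccc4[nH]ccc4c3)nc21`: 300 nM

Compound 2 holds the lower of the two numbers. Compound 3 `Cn1c(=O)c(S(=O)(=O)Nc2ccc(F)cc2)cc2cnc(Nc3ccc4[nH]ccc4c3)nc21` differs from it by one change: (4-fluorophenyl)amino in place of 4-fluorophenyl on a sulfonyl sulfur. Among the measured compounds shown here, one measured step bears on this, the large 17-fold lower number from compound 1 to compound 2 (1.22 log units; beyond the scatter), with (4-fluorophenyl)sulfonyl in place of (4-fluorophenyl)carbamoyl. Compound 3 keeps the sulfonyl of compound 2 but regains the nitrogen found in compound 1, so a moderate rise in this assay is expected, smaller than that step. The expected change is a 3.3-fold higher number from compound 2 to compound 3 (0.52 log units; beyond the scatter). Compound 3 is estimated at 1000 nM, with an expected range of 200 nM to 5000 nM.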

Compound 3, half-maximal inhibitory concentration: 5000 nM
Beside the measured number, compound 3's estimate is 5.0-fold (0.70 log units) below it, and the stated range covers the measured number.
By their numbers in this assay, from the lowest: compound 2; then compounds 1 and 3 (each within the scatter of the next).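

In this account, swapping in (4-fluorophenyl)amino on the sulfonyl sulfur gives a 17-fold higher number from compound 2 to compound 3 (1.22 log units; beyond the scatter) in this assay and so removes the whole advantage of compound 2. The sulfamoyl and carbamoyl compounds then read alike, with no change at the digits printed from compound 1 to compound 3 (within the scatter) and so, among these three, only compound 2, with 4-fluorophenyl directly on the sulfonyl sulfur, stands apart. No evidence given here accounts for this result.

On these data alone, whether a methylene in place of that nitrogen, or a methyl on it, would read like compound 2 or like compound 3 stays open.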